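Thiophen-2-yl to 5-methylfuran-2-yl: a step still to be measured

A few compounds are considered here, and "the series" means these few. Any claim that something is new, unique, unknown or untested is made for them only; others in the source may bear on it.

Of the compounds shown here, three built on one shared core have been tested in a functional assay on Ehrlich cells (Mus musculus) for cytotoxicity, tested at 10 ug/mL; on this read-out lower numbers stand for a weaker effect and higher numbers for a stronger effect at the one concentration tested. Compound 1 `COc1cc(N2C(N)=C(C#N)C(c3ccccc3O)C3=C2CC(C)(C)CC3=O)cc(OC)c1OC` gives 0% in this assay. Compound 2 `COc1cc(N2C(N)=C(C#N)C(c3ccc(Cl)cc3Cl)C3=C2CC(C)(C)CC3=O)cc(OC)c1OC` gives 20% in this assay. Compound 3 `COc1cc(N2C(N)=C(C#N)C(c3cccs3)C3=C2CC(C)(C)CC3=O)cc(OC)c1OC` gives 5% in this assay, which places it second highest of the three numbers: its nearest neighbour is compound 1, with a number 5 percentage points higher from compound 1 to compound 3 (within the scatter), and its furthest is compound 2, with a number 15 percentage points lower from compound 2 to compound 3 (beyond the scatter).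

Compound 4 `COc1cc(N2C(N)=C(C#N)C(c3ccc(C)o3)C3=C2CC(C)(C)CC3=O)cc(OC)c1OC` has not yet been measured in this assay. It differs from compound 3 in one place: 5-methylfuran-2-yl in place of thiophen-2-yl on a saturated ring carbon. Every step measured so far concerns exactly this saturated ring carbon, so all of them bear on the change. Two of them, a number 20 percentage points higher from compound 1 to compound 2 (beyond the scatter) and a number 15 percentage points lower from compound 2 to compound 3 (beyond the scatter), were modest, and one, a number 5 percentage points higher from compound 1 to compound 3 (within the scatter), stayed within the scatter. Within the data shown here, no measured compound carries a furan, so nothing singles the new group out. A step within the scatter is therefore expected, a number 3 percentage points higher from compound 3 to compound 4 (within the scatter), with no clear direction. Compound 4 is expected to give about 8% in this assay, in a range from 0% to 25%.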

Compound 4, a percentage reported as activity, at one concentration (the size of the read-out at that concentration, not a potency): 21%
Estimate against measurement, compound 4: 13 percentage points below, within the range that was stated.
By their numbers in this assay, from the lowest: compounds 1 and 3 (each within the scatter of the next); then compounds 2 and 4 (each within the scatter of the next).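

In this assay, the change on the saturated ring carbon gave a number 16 percentage points higher from compound 3 to compound 4 (beyond the scatter), so thiophen-2-yl and 5-methylfuran-2-yl do not behave alike at this position, although both are five-membered aromatic rings with one hetero atom and the same counts of hydrogen-bond donors and acceptors. Before this result, only the 2,4-dichlorophenyl group of compound 2 stood clear of the others, but the new group shows a number 1 percentage points higher from compound 2 to compound 4 (within the scatter) and also a number 21 percentage points higher from compound 1 to compound 4 (beyond the scatter), so a number of this size at this position is not tied to the 2,4-dichlorophenyl group. No measurement available here accounts for the gap between the two five-membered groups.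

The compounds shown leave open whether the step belongs to the oxygen in place of sulfur or to the added methyl group, as the change brings both at once, and the plain furan-2-yl and 5-methylthiophen-2-yl groups would separate the two. They also leave open how a five-membered ring carrying an amine or a carboxylic acid, or a longer chain in place of the methyl, would read at this carbon.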